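The compounds below may be only part of what the source reports. "The series", "measured", "known", "first", "only" and "open" are said of these compounds alone.

Measured so far in a functional assay on MCF7 cells (Homo sapiens) for antiproliferative activity, read by trypan blue exclusion, with a stated time of 24 h; a higher number here means a weaker inhibitor, a lower number a stronger inhibitor:
compound 1, `COC(=O)c1ccc(Cn2cc(/C=C3\NC(=O)NC3=O)c3ccccc32)cc1`: 15400 nM
compound 2, `O=C1NC(=O)/C(=C/c2cn(Cc3ccccc3)c3ccc(Cl)cc23)N1`: 9200 nM

Compound 2 holds the lower of the two numbers, but compound 1 sits close by, within the scatter, so no order between them is claimed. Compound 3, `COc1ccc2c(c1)c(/C=C1\NC(=O)NC1=O)cn2Cc1ccccc1`, follows from compound 2 by one change: methoxy in place of chloro on an aromatic carbon. Among the measured compounds shown here, no measured pair shows this change, so its size is unknown; in this assay a small step toward a higher number, not clearly beyond the scatter, is expected. For compound 3 the estimated value in this assay is 12000 nM, within 4000 nM to 40000 nM. The step of a 1.3-fold higher number from compound 2 to compound 3 (0.12 log units; within the scatter) is expected to stay close to the scatter.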

Compound 3, half-maximal inhibitory concentration: 7200 nM
Estimate against measurement, compound 3: 1.7-fold (0.22 log units) above, and the stated range covers the measured number.
By their numbers in this assay, from the lowest: compounds 3, 2 and 1 (each within the scatter of the next, the first and the last beyond it).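

In this assay, methoxy in place of chloro on this aromatic carbon gives a 1.3-fold lower number from compound 2 to compound 3 (0.11 log units; within the scatter) and so separates the two groups by no more than the scatter, although methoxy carries a hydrogen-bond acceptor and chloro none. Among the compounds shown here, this is the first reading of a change at this position, and it shows that the position tolerates this exchange without a clear shift in the number. Nothing at hand accounts for this result. Still open, going by these compounds, is whether an amine or a carboxylic acid on this carbon would move the number beyond the scatter.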